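Benzyl for phenoxy on the shared core: cytotoxicity

A few compounds are considered here, and "the series" means these few. Any claim that something is new, unique, unknown or untested is made for them only; others in the source may bear on it.

Compound 1 `COc1cccc(Oc2ccc3c(NCCCNCc4cccc(OC)c4O)ccnc3c2)c1`: 5300 nM
Compound 2 `COc1cccc(CNCCCNc2ccnc3cc(Oc4ccc(F)cc4)ccc23)c1O`: 11000 nM

In an ADME assay on HepG2 cells (Homo sapiens) for cytotoxicity, read by luminescence, CellTiter-Glo and ATP content, with a stated time of 72 h (on this read-out lower numbers stand for an effect already at smaller amounts and higher numbers for an effect only at larger amounts of compound), compound 2 gives 11000 nM, the highest of the two numbers; its nearest neighbour is compound 1 with 5300 nM, and a 2.1-fold higher number from compound 1 to compound 2 (0.32 log units; beyond the scatter) separates them. Compound 3 `COc1cccc(CNCCCNc2ccnc3cc(Cc4ccc(F)cc4Cl)ccc23)c1O` is not yet measured; it differs from compound 2 by 2-chloro-4-fluorobenzyl in place of 4-fluorophenoxy on an aromatic carbon. For the measured compounds named here, that change is of another kind than the swap on the oxygen measured so far, so no measured step bears on it directly. Both measured values sit close together. The step of a 1.2-fold lower number from compound 2 to compound 3 (0.09 log units; within the scatter) is expected to stay within the scatter. For compound 3 the estimate is 9000 nM, with a range from 3500 nM to 25000 nM.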

Compound 3, half-maximal effective concentration: 2350 nM
Beside the measured number, compound 3's estimate is 3.8-fold (0.58 log units) above it, and the stated range ends above it.
By their numbers in this assay, from the lowest: compound 3; then compound 1; then compound 2.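

At this aromatic carbon, in this assay 2-chloro-4-fluorobenzyl lowers the number against both phenoxy groups: against 4-fluorophenoxy (a 4.7-fold lower number from compound 2 to compound 3 (0.67 log units; beyond the scatter)) and against 3-methoxyphenoxy (a 2.3-fold lower number from compound 1 to compound 3 (0.35 log units; beyond the scatter)). For the compounds shown here, the swap on the oxygen compared only two phenoxy groups, whereas these steps show that replacing the phenoxy group with this benzyl group moves the number down from either compound. Nothing available explains this shift.

As far as these compounds go, whether the carbon in place of the oxygen or the added chlorine carries the step remains open, as both change together. From the compounds shown here alone, how an amine or a carboxylic acid at this carbon would read is also open.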